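Shortening the Amino Ester on an Inactive Core

This account rests on a few compounds, and the source may have more. Where it says the series, first, only, none or still open, it means among the compounds named here.

Compound 2 `C=C1CC[C@H]2[C@@](C)(CC[C@@H](OC(=O)[C@H](N)CC(C)C)[C@@]2(C)NC=O)[C@@H]1/C=C/C1=CCOC1=O` carries a 1-amino-3-methylbutyl group on the carbonyl carbon of its ester. In an assay for inhibition of hexokinase-2 (Homo sapiens), read by coupled enzyme assay, with a stated time of 10 min, in the presence of a further agent that is not named here (a lower number here means a stronger inhibitor, a higher number a weaker inhibitor), compound 2 reaches only the limit of > 50000 nM, so no number is known for it. Compound 1 `C=C1CC[C@H]2[C@@](C)(CC[C@@H](OC(=O)c3ccc([N+](=O)[O-])cc3)[C@@]2(C)NC=O)[C@@H]1/C=C/C1=CCOC1=O` sits at the same limit, giving > 50000 nM in this assay. The step that the two limits leave unreadable from compound 1 to compound 2 therefore cannot be read. Compound 3 `C=C1CC[C@H]2[C@@](C)(CC[C@@H](OC(=O)CNC)[C@@]2(C)NC=O)[C@@H]1/C=C/C1=CCOC1=O` differs by (methylamino)methyl in place of 1-amino-3-methylbutyl on a carbonyl carbon. Because the limit of > 50000 nM in this assay, at which 2 of the 2 values shown sit, is where both measured values stand, the expected step is a number no higher from compound 2 to compound 3 (the limit leaves the size open), with no readable direction. Compound 3 is expected to give 50000 nM in this assay, between 20000 nM and 100000 nM.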

Compound 3, half-maximal inhibitory concentration: > 50000 nM
Compound 3 was reported as a limit; the forecaster's own chance of this, stated with the estimate: 80%; the middle value sits exactly at the limit.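

Compound 1, compound 2 and compound 3 each give only a limit, not a number, so no step among them can be read: the limit of > 50000 nM in this assay, at which 3 of the 3 values shown sit.

The compounds shown leave open whether any group on this carbonyl carbon of the shared core would give a measurable number.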